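Propyl for hydrogen on two cores: a chain extension

This account rests on a few compounds, and the source may have more. Where it says the series, first, only, none or still open, it means among the compounds named here.

Compound 1 `CC(=O)Nc1ccc2[nH]c(C)nc2c1` and compound 2 `CCCCC(=O)Nc1ccc2[nH]c(C)nc2c1` share one core; in a physicochemical assay for lipophilicity (on this read-out higher numbers stand for higher lipophilicity and lower numbers for lower lipophilicity), compound 1 gives 0.61 and compound 2 gives 2.11, so the change propyl in place of hydrogen on a saturated chain carbon bound to a carbonyl carbon brought a number 1.50 log units higher from compound 1 to compound 2 (beyond the scatter). Compound 3 `CCCCc1nc2cc(C)c(C)cc2[nH]1` stands on a different core; how the two cores differ is not broken down here. In this assay compound 3 gives 3.9, the highest of the three values. Compound 4 `CCCCCCCc1nc2cc(C)c(C)cc2[nH]1` carries the same kind of change as compound 2, namely (propyl in place of hydrogen on a saturated chain carbon, four bonds along the chain from an aromatic carbon), but the place differs: on a saturated chain carbon bound to a carbonyl carbon in compound 2, on a saturated chain carbon four bonds along the chain from an aromatic carbon in compound 4. Among the measured compounds shown here, a step of about a number 1.50 log units higher from compound 3 to compound 4 (beyond the scatter) is expected because a number 1.50 log units higher from compound 1 to compound 2 (beyond the scatter) stands as the only step of this kind. Compound 4 is therefore estimated at 5.4, between 4.9 and 5.9.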

Compound 4, partition coefficient: 5.4
The estimate for compound 4 equals the measured number at the digits printed; low and high end bracket the measured number.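

In this assay the change of hydrogen to propyl gave a number 1.50 log units higher from compound 3 to compound 4 (beyond the scatter), matching at the digits printed a number 1.50 log units higher from compound 1 to compound 2 (beyond the scatter), so the step carried over in size from one core to the other, although the chain carbon bearing the change differs. Two pairs show agreement on these two cores only and do not establish a fixed increment across the series. Nothing measured here bears on why the two steps agree.

The compounds shown leave open whether the same step would hold on a third core or with a longer chain. They also leave open what an amine or a carboxylic acid on the end of the chain would do to this read-out.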